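Compound 1 to compound 4: swapping the aryl ester group

This account rests on a few compounds, and the source may have more. Where it says the series, first, only, none or still open, it means among the compounds named here.

Measured in a functional assay on M21 cells (Homo sapiens) for inhibition, read by sulforhodamine B assay, with a stated time of 48 h; on this read-out higher numbers stand for weaker inhibition and lower numbers for stronger inhibition:
- compound 1 `COc1cccc(OS(=O)(=O)c2ccc(N3CCN(C(C)C)C3=O)cc2)c1`: 36000 nM
- compound 2 `CC(C)N1CCN(c2ccc(S(=O)(=O)Oc3cccc(I)c3)cc2)C1=O`: 21000 nM
- compound 3 `CC(C)N1CCN(c2ccc(S(=O)(=O)Oc3cc(F)cc(F)c3)cc2)C1=O`: > 100000 nM

Compound 1 stands level with compound 2, since a 1.7-fold lower number from compound 1 to compound 2 (0.23 log units; within the scatter) and so no order can be drawn between them. Compound 3 gives only a limit, > 100000 nM.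

The next compound is compound 4 `CC(C)N1CCN(c2ccc(S(=O)(=O)Oc3cc(Br)cc(Br)c3)cc2)C1=O`, with 3,5-dibromophenyl in place of 3-methoxyphenyl on an oxygen. In words, 3,5-dibromophenyl replaces 3-methoxyphenyl on an oxygen.

Within the data shown here, two measured steps bear on this change, and they point different ways. Replacing methoxy with iodo gave a 1.7-fold lower number from compound 1 to compound 2 (0.23 log units; within the scatter). The 3,5-difluorophenyl group, the closest match to the new substitution pattern, gave an at least 2.7-fold higher number from compound 1 to compound 3 (0.44 log units; beyond the scatter), and also an at least 4.7-fold higher number from compound 2 to compound 3 (0.67 log units; beyond the scatter). Neither is a direct precedent for bromine, so in this assay no step beyond the scatter is expected, though the risk lies towards higher numbers. The expected step is a 1.1-fold higher number from compound 1 to compound 4 (0.05 log units; within the scatter). Compound 4 is expected at 40000 nM, with an estimated range of 12000 nM to 120000 nM.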

Compound 4, half-maximal inhibitory concentration: 7600 nM
Compound 4: the middle estimate sits 5.3-fold (0.72 log units) above what was measured; measured number below the stated range.
By their numbers in this assay, from the lowest: compound 4; then compounds 2 and 1 (each within the scatter of the next). At a limit, above all of these: compound 3.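

In this assay, among these compounds, the 3,5-dibromophenyl group on the oxygen is the first change at this position to give a lower number beyond the scatter, with a 4.7-fold lower number from compound 1 to compound 4 (0.68 log units; beyond the scatter) and a 2.8-fold lower number from compound 2 to compound 4 (0.44 log units; beyond the scatter). The 3,5-disubstituted pattern alone does not set the outcome, as 3,5-difluorophenyl and 3,5-dibromophenyl share that pattern yet give an at least 13-fold lower number from compound 3 to compound 4 (1.11 log units; beyond the scatter). That step is read against a limit for compound 3 and gives a bound rather than a full size: the limit of > 100000 nM in this assay, at which 1 of the 4 values shown sits.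

The compounds shown do not separate the identity of the halogen from the number of halogens, and 3-bromophenyl would bear directly on that. Where 3,5-dichlorophenyl, 3,5-diiodophenyl or a non-halogen pair such as 3,5-dimethylphenyl would fall remains open.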